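The source may report more compounds than this note shows. Statements on the series, on what has been measured and on what is new or still open speak of the compounds shown alone.

Measured so far:
compound 1 `O=C(CN(CC1CC1)C(=O)c1ccc(-c2ccccn2)cc1)Nc1cc(F)cc(F)c1`, 200 nM in an assay on HEK293 cells for inhibition of sodium- and chloride-dependent glycine transporter 1 (Homo sapiens), read by scintillation proximity assay; a higher number here means a weaker inhibitor, a lower number a stronger inhibitor
compound 2 `COCC(C)N(CC(=O)Nc1cc(F)cc(F)c1)C(=O)c1ccc(-c2ccccn2)cc1`, 1260 nM in this assay

Within the data shown here, compound 2 gives the higher of the two numbers; the only step toward it, a 6.3-fold higher number from compound 1 to compound 2 (0.80 log units; beyond the scatter), swaps the whole group on the amide-type nitrogen. Compound 3 `CCC(COC)N(CC(=O)Nc1cc(F)cc(F)c1)C(=O)c1ccc(-c2ccccn2)cc1` differs from compound 2 only by methyl in place of hydrogen on a saturated chain carbon, two bonds along the chain from an amide-type nitrogen. Among the measured compounds shown here, no measured step touches this smaller change, so the data give no direct guide; compound 2 is the starting point, and a step no larger than the scatter is expected, meaning a 1.0-fold higher number from compound 2 to compound 3 (0.01 log units; within the scatter). Compound 3 is therefore estimated at 1300 nM, within 500 nM to 3500 nM.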

Compound 3, half-maximal inhibitory concentration in the sodium- and chloride-dependent glycine transporter 1 assay: 1260 nM
Compound 3: the middle estimate sits 1.0-fold (0.01 log units) above what was measured, and the stated range covers the measured number.
By their numbers in the sodium- and chloride-dependent glycine transporter 1 assay, from the lowest: compound 1; then compounds 2 and 3 (each within the scatter of the next).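

In the sodium- and chloride-dependent glycine transporter 1 assay, adding the methyl on this chain carbon gives no change at the digits printed from compound 2 to compound 3 (within the scatter), and swapping cyclopropylmethyl for 1-(methoxymethyl)propyl still gives a 6.3-fold higher number from compound 1 to compound 3 (0.80 log units; beyond the scatter). So this position accepts one more carbon without any visible change in this assay, and the larger chain does not close the gap. The same methyl does register in a physicochemical assay for solubility, read by chemiluminescence (on this read-out lower numbers stand for lower solubility and higher numbers for higher solubility), where compound 2 gives 58 ug/mL and compound 3 gives 24 ug/mL and the reading falls: the measured solubility of compound 2, 58 ug/mL, and of compound 3, 24 ug/mL, a 2.4-fold lower number (0.38 log units; beyond the scatter)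

On these data alone, whether an amine or a carboxylic acid on this chain carbon would leave the number in the sodium- and chloride-dependent glycine transporter 1 assay as it is, or lift the reading in the physicochemical assay, stays open. So does whether any such group could bring the number back toward that of compound 1.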